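Pyridinylmethyl for a bis(dimethylaminoethyl) side chain in a sulfamate series

The source may report more compounds than this note shows. Statements on the series, on what has been measured and on what is new or still open speak of the compounds shown alone.

Of the compounds shown here, three sharing one sulfamate core have been measured in an assay on HEK293 cells for inhibition of Steryl-sulfatase (Homo sapiens), tested at 0.1 uM; a lower number here means a weaker effect, a higher number a stronger effect of the compound at the concentration tested. Compound 1 `CN(C)CCN(CCN(C)C)c1cccc(C(=O)N2CCc3ccc(OS(N)(=O)=O)cc3C2)c1` gives 0%, the lowest of the three numbers. Compound 2 `CN(CCCN1CCCCC1)c1ccc(C(=O)N2CCc3ccc(OS(N)(=O)=O)cc3C2)cc1` gives 17.4%, and compound 3 `CCN(Cc1cccc(Br)c1)c1ccc(C(=O)N2CCc3ccc(OS(N)(=O)=O)cc3C2)cc1` gives 80.2%, so compound 1 lies beyond the scatter below both, with compound 2 nearest and compound 3 furthest.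

Compound 4 `CCN(Cc1ccccn1)c1cccc(C(=O)N2CCc3ccc(OS(N)(=O)=O)cc3C2)c1` is not yet measured. Compared with compound 1 the change is ethyl((pyridin-2-yl)methyl)amino in place of bis(2-(dimethylamino)ethyl)amino on an aromatic carbon. Going by the values given here, only one measured step bears on it: the change from a side chain carrying a basic aliphatic amine to an amine bearing an aromatic ring gave a number 62.8 percentage points higher from compound 2 to compound 3 (beyond the scatter). That step sits on another arrangement of the shared core and swaps in a brominated benzyl rather than a pyridinylmethyl group, so it is a partial guide only, and the starting number of compound 1 is already at the floor of the read-out.

He therefore expects a large rise in this assay, though smaller than the measured one, and estimates compound 4 at 45% with a range from 15% to 75%, a step of a number 45 percentage points higher from compound 1 to compound 4 (beyond the scatter) that is expected rather than known.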

Compound 4, a percentage reported as inhibition, at one concentration (the size of the read-out at that concentration, not a potency): 6.5%
For compound 4 the middle estimate is 38.5 percentage points above the measured one; measured number below the stated range.
By their numbers in this assay, from the lowest: compounds 1 and 4 (each within the scatter of the next); then compound 2; then compound 3.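

In this assay, ethyl((pyridin-2-yl)methyl)amino in place of bis(2-(dimethylamino)ethyl)amino, at the place meta to a large group, gives a number 6.5 percentage points higher from compound 1 to compound 4 (within the scatter) and so leaves the two compounds indistinguishable in this read-out. Bringing in a six-membered aromatic ring with 1 hetero atom at this place therefore does not, on its own, reproduce a number 62.8 percentage points higher from compound 2 to compound 3 (beyond the scatter) seen on the other arrangement of the shared core, so that step does not carry over to this change. Nothing available here accounts for this outcome.

The compounds shown leave open whether the missing gain belongs to the place on the ring or to the group itself, a question that (3-bromobenzyl)(ethyl)amino at the place held by the side chain of compound 4 would address directly. They also leave open whether the ring nitrogen of the pyridine matters, which an ethyl(benzyl)amino group or a bromine on the pyridine ring at this same place would begin to separate.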